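Aryl Substituent Variation in the Shared Core Series

The source may hold more compounds than are shown below. What is called first, only, known or untested is meant among the compounds shown, and "the series" means these compounds.

Compound 1 `CCC(COc1cccc(F)c1)OC(=O)NCc1ccccc1`: in an assay for inhibition of zeta-carotene desaturase, chloroplastic/chromoplastic (Capsicum annuum), using a Dixon plot, with a stated time of 8 h (on this read-out lower numbers stand for stronger inhibition and higher numbers for weaker inhibition), compound 1 reaches only the assay limit, > 100000 nM.
Compound 2 `CCC(COc1cccc([N+](=O)[O-])c1)OC(=O)NCc1ccccc1`: in this assay compound 2 reaches only the assay limit, > 100000 nM.
Compound 3 `CCC(COc1cccc(C)c1)OC(=O)NCc1ccccc1`: in this assay compound 3 reaches only the assay limit, > 100000 nM.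

Compound 3 stands at the limit, as do the other two measured compounds, all three sitting at the limit of > 100000 nM in this assay, at which 3 of the 3 values shown sit. The steps a step that the two limits leave unreadable from compound 1 to compound 2, a step that the two limits leave unreadable from compound 1 to compound 3 and a step that the two limits leave unreadable from compound 2 to compound 3 are therefore not readable in size or direction. Compound 4 `CCC(COc1cccc(C(C)C)c1)OC(=O)NCc1ccccc1` differs from compound 3 by isopropyl in place of methyl on an aromatic carbon. All measured steps bearing on this change are aryl substituent exchanges that remained unreadable, so no readable gain is expected from compound 3 to compound 4, with the step expected as a step that the limit leaves unreadable from compound 3 to compound 4. Compound 4 is expected at 150000 nM, within 50000 nM to 500000 nM.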

Compound 4, half-maximal inhibitory concentration: > 100000 nM
Compound 4: no number, only a limit; the forecaster's own chance of this, stated with the estimate: 85%; the middle value is on the limit's open side.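

For the compounds shown here, no step from compound 1, compound 2 or compound 3 to compound 4 can be read, since all four compounds stand at a limit: the limit of > 100000 nM in this assay, at which 4 of the 4 values shown sit. The compounds shown leave open whether any aryl substituent on the shared core gives a readable value, and how these substituents rank.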